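Phenyl for propyl on a weakly active chain

The compounds below may be only part of what the source reports. "The series", "measured", "known", "first", "only" and "open" are said of these compounds alone.

Of the compounds shown here, three have been measured in a functional assay on HCT-116 cells (Homo sapiens) for antiproliferative activity, read by CCK-8 assay, with a stated time of 72 h, tested at 2 uM; on this read-out higher numbers stand for a stronger effect at the one concentration tested and lower numbers for a weaker effect. Compound 1 `Nc1ccccc1NC(=O)/C=C/c1ccc(Cn2cnc3c(Nc4cccc(Cl)c4)nc(Cl)nc32)cc1` gives 12.9%. Compound 2 `CCCCn1cnc2c(NCc3ccc(C(=O)Nc4ccccc4N)cc3)nc(Cl)nc21` gives 4.89%. Compound 3 `Nc1ccccc1NC(=O)/C=C/c1ccc(COCNc2nc(Nc3cccc(Cl)c3)c3ncn(C4CCCC4)c3n2)cc1` gives 9.04%. All three numbers are small, and the gaps between them fall within the usual scatter of this kind of measurement, so nothing can be said about which of them acts more strongly: compound 2 simply sits alongside compounds 1 and 3 in the low range.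

Compound 4 `Nc1ccccc1NC(=O)c1ccc(CNc2nc(Cl)nc3c2ncn3Cc2ccccc2)cc1` has not yet been tested. It differs from compound 2 in one place: phenyl in place of propyl on a saturated chain carbon bound to an aromatic nitrogen. The chain on the saturated carbon bound to the aromatic nitrogen thus gains a ring, the same change that reads butyl to benzyl when cut one bond further out.

For the measured compounds named here, no pair of measured compounds differs in only this one place, so there is no measured step to lean on. Compound 1, which also carries a benzyl-type group on that nitrogen, gives 12.9%, a number within the scatter of compound 2. The expected step of a number 4.1 percentage points higher from compound 2 to compound 4 (within the scatter) is therefore small, if anything slightly upward, and not beyond the scatter. Compound 4 is estimated at 9%, in a range from 0% to 22%.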

Compound 4, a percentage reported as inhibition, at one concentration (the size of the read-out at that concentration, not a potency): 7.7%
The estimate for compound 4 lay 1.3 percentage points above the measured number; low and high end bracket the measured number.
By their numbers in this assay, from the lowest: compounds 2, 4, 3 and 1 (each within the scatter of the next).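

In this assay, phenyl in place of propyl on a saturated chain carbon bound to an aromatic nitrogen gives a number 2.8 percentage points higher from compound 2 to compound 4 (within the scatter). For the compounds shown here, this is the first measured pair that differs in only one place, so this position can now be judged directly: in the same way as butyl to benzyl, the change brings in a six-membered aromatic ring of carbon only, yet the two compounds cannot be told apart at the one concentration tested. No measurement shown here accounts for this result or bears on it.

Going by these compounds alone, the pair shows only that this one swap gives no step beyond the usual scatter, and with both numbers low, it gives no measure of potency for either compound. From the compounds shown here alone, whether a longer chain such as hexyl, or an amine or a carboxylic acid carried on the chain at this nitrogen, would give a step beyond the scatter remains open.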